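Swapping methylamino for methyl at a limit value

The source may hold more compounds than are shown below. What is called first, only, known or untested is meant among the compounds shown, and "the series" means these compounds.

Measured in a functional assay on A549 cells (Homo sapiens), read by MTT assay, with a stated time of 72 h; on this read-out higher numbers stand for weaker inhibition and lower numbers for stronger inhibition:
Compound 1 `CNc1ncnc2c1c(-c1ccco1)cn2[C@@H]1O[C@H](CO)[C@@H](O)[C@H]1O`: 2570 nM
Compound 2 `CNc1ncnc2c1c(-c1ccoc1)cn2[C@@H]1O[C@H](CO)[C@@H](O)[C@H]1O`: > 20000 nM
Compound 3 `C#Cc1cn([C@@H]2O[C@H](CO)[C@@H](O)[C@H]2O)c2ncnc(NC)c12`: > 20000 nM

Compound 2 gives no number, only a limit: > 20000 nM. That is the limit of > 20000 nM in this assay, at which 2 of the 3 values shown sit. Compound 4 `Cc1ncnc2c1c(-c1ccoc1)cn2[C@@H]1O[C@H](CO)[C@@H](O)[C@H]1O` differs from compound 2 in one place: methyl in place of methylamino on an aromatic carbon. Among the measured compounds shown here, no measured step touches this group. The two readable steps, an at least 7.7-fold higher number from compound 1 to compound 2 (0.89 log units; beyond the scatter) and an at least 7.7-fold higher number from compound 1 to compound 3 (0.89 log units; beyond the scatter), both concern the other substituent, and they show that this assay responds to a single change on the shared core. A small shift towards a lower number is therefore expected, as the estimated at least 1.2-fold lower number from compound 2 to compound 4 (0.09 log units; that floor lies within the scatter). Compound 4 is expected at about 16000 nM, within an estimated range of 4000 nM to 40000 nM.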

Compound 4, half-maximal inhibitory concentration: > 20000 nM
Compound 4 gave a limit, no number (the forecaster's own chance of this, stated with the estimate: 55%); middle value at least 1.2-fold (0.09 log units) away from the limit.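

Compound 2 and compound 4 both sit at a limit in this assay, so no step can be read between them: the limit of > 20000 nM in this assay, at which 3 of the 4 values shown sit.

The compounds shown leave open whether methyl in place of methylamino changes the read-out in this assay at all.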